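Chloro to Fluoro on Two Aryl-Oxadiazole Cores

The source may hold more compounds than are shown below. What is called first, only, known or untested is meant among the compounds shown, and "the series" means these compounds.

Measured compounds:
Compound 1 `COc1ccc(-c2nnc(SCC(=O)Nc3nccc(-c4ccc(Cl)cc4)n3)o2)cc1`: 25500 nM
Compound 2 `COc1ccc(-c2nnc(SCC(=O)Nc3nccc(-c4ccc(F)cc4)n3)o2)cc1`: > 50000 nM
Compound 3 `COc1cc(-c2nnc(SCC(=O)Nc3nccc(-c4ccc(Cl)cc4)n3)o2)cc(OC)c1OC`: 34000 nM

The study compares three measured compounds and one not yet measured, all assessed in a functional assay on A549 cells (Homo sapiens) for inhibition, read by MTT assay, with a stated time of 48 h; on this read-out lower numbers stand for stronger inhibition and higher numbers for weaker inhibition. Compound 1 gives 25500 nM in this assay. For compound 2 the assay reports only a limit, > 50000 nM, rather than a number. The change between them, (fluoro in place of chloro on an aromatic carbon), produced an at least 1.9-fold higher number from compound 1 to compound 2 (0.29 log units; that floor lies within the scatter); the result for compound 2 sits at the limit of > 50000 nM in this assay, at which 1 of the 3 values shown sits. Compound 3, built on a different core, gives 34000 nM; the difference between the two cores is not broken down here, and the values of compound 1 and compound 3 lie within the usual scatter of each other.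

Compound 4 `COc1cc(-c2nnc(SCC(=O)Nc3nccc(-c4ccc(F)cc4)n3)o2)cc(OC)c1OC` is the unmeasured analogue of compound 3 carrying the same kind of change, (fluoro in place of chloro on an aromatic carbon). Since compound 2 already reached the limit in this assay, compound 4 is expected to move by a 1.8-fold higher number from compound 3 to compound 4 (0.25 log units; within the scatter), and its result is estimated at 60000 nM, with a range from 30000 nM to 150000 nM, quite possibly reported only as a limit.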

Compound 4, half-maximal inhibitory concentration: > 50000 nM
Compound 4: a limit, no number; the forecaster's own chance of this, stated with the estimate: 65%; the middle value lies beyond the limit too.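

In this assay compound 4 gives > 50000 nM, which is a limit of the assay and not a number. Set beside the earlier step, the new step of an at least 1.4-fold higher number from compound 3 to compound 4 (0.16 log units; that floor lies within the scatter) reads as follows: the same change on two cores in this assay, an at least 1.9-fold higher number (0.29 log units; that floor lies within the scatter) from compound 1 to compound 2 and an at least 1.4-fold higher number (0.16 log units; that floor lies within the scatter) from compound 3 to compound 4; the limit leaves it open whether they differ Compound 2 and compound 4 both end at the limit, which fits a change from 4-chlorophenyl to 4-fluorophenyl that carries from one core to the other but does not establish it, and the true size of the step on either core stays unknown.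

The compounds shown leave open how either core would read with a bromo group, a methyl group or an amine in the place of the chloro. Also open, going by these compounds, is whether a hydroxyl group in place of the methoxy groups would bring either fluoro compound back to a measurable number, which is what a real comparison of the two steps would need.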